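Epimeric step in a weak somatostatin receptor series

The source may hold more compounds than are shown below. What is called first, only, known or untested is meant among the compounds shown, and "the series" means these compounds.

Measured compounds:
compound 1 `CS[C@@H]1O[C@H](COCc2ccc(Cl)cc2)[C@@H](O)[C@@H](OCc2ccc3ccccc3c2)[C@H]1NC(=O)CCN` gives 9590 nM
compound 2 `COC[C@H]1O[C@H](OCCc2ccccc2)[C@H](NC(=O)CCCN)[C@H](OCc2ccc3ccccc3c2)[C@@H]1O` gives > 10000 nM

Compound 1 was measured in an assay on CHO cells for displacement of a labelled ligand from somatostatin receptor type 1 (Homo sapiens) (a lower number here means a stronger inhibitor, a higher number a weaker inhibitor), and sits just inside the measurable range. For compound 2 this assay reports only a limit, > 10000 nM, so compound 2 stands at the limit of > 10000 nM in this assay, at which 1 of the 2 values shown sits, and no number is known for it. For the measured compounds named here, no step between the two measured compounds is defined, since they differ in more than one place; their two values show only that both are weak inhibitors, one with a number and one at the limit.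

Compound 3 `COC[C@H]1O[C@@H](OCCc2ccccc2)[C@H](NC(=O)CCCN)[C@@H](OCc2ccc3ccccc3c2)[C@@H]1O` is the compound still to be measured. Relative to compound 2 the change is the two compounds have the same atoms and bonds and differ only in configuration as drawn: 2 of 5 stereo elements differ; a stereocentre at a saturated ring carbon is drawn S in compound 2 and R in compound 3; a stereocentre at a saturated ring carbon is drawn S in compound 2 and R in compound 3. Nothing measured here bears on what an inversion of configuration does in this assay, and compound 2 itself has only a limit. The step from compound 2 to compound 3 is therefore expected to be a step that the limit leaves unreadable from compound 2 to compound 3, with no direction favoured beyond the scatter. For compound 3 the estimate in this assay is 12000 nM, within 4000 nM to 40000 nM, and a result reported only as a limit is considered likely.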

Compound 3, half-maximal inhibitory concentration: > 10000 nM
Compound 3: a limit, no number (the forecaster's own chance of this, stated with the estimate: 60%); the middle value does not contradict the limit.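

In this assay compound 3 gives > 10000 nM, which is a limit and not a number. Compound 2 also has only a limit, so no step can be read between compound 2 and compound 3. The compounds shown leave open what the change of configuration at the two stereocentres does in this assay.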